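The compounds below may be only part of what the source reports. "The series", "measured", "known", "first", "only" and "open" are said of these compounds alone.

Measured values in a functional assay on A549 cells (Homo sapiens) for antiproliferative activity, read by MTT assay, with a stated time of 72 h (on this read-out lower numbers stand for stronger inhibition and higher numbers for weaker inhibition), are these:
- compound 1 (`COc1cc(C(=O)c2sc3ccccc3c2-c2ccccc2)cc(OC)c1OC`) gives 5000 nM
- compound 2 (`CCOc1ccc(-c2c(C(=O)c3cc(OC)c(OC)c(OC)c3)sc3ccccc23)cc1`) gives 3100 nM
- compound 3 (`COc1cc(C(=O)c2sc3ccccc3c2Nc2ccccc2)cc(OC)c1OC`) gives 3000 nM

Compound 3 cannot be told apart from the other two: both the step (a 1.0-fold lower number from compound 2 to compound 3 (0.01 log units; within the scatter)) and the step (a 1.7-fold lower number from compound 1 to compound 3 (0.22 log units; within the scatter)) stay within the usual scatter of such measurements. The next compound, compound 4 (`COc1cc(C(=O)c2sc3ccccc3c2Nc2ccc(C)cc2)cc(OC)c1OC`), has not yet been measured. It differs from compound 3 by methyl in place of hydrogen on an aromatic carbon, para to a large group (methyl in place of hydrogen on an aromatic carbon). The closest measured change (a 1.6-fold lower number from compound 1 to compound 2 (0.21 log units; within the scatter)) also replaces hydrogen on an aromatic carbon, though with ethoxy, and it too stays within the scatter. For the measured compounds named here, no measured compound carries methyl, so this guidance is limited. No step beyond the scatter is therefore expected in this assay, and the estimated step (a 1.2-fold lower number from compound 3 to compound 4 (0.08 log units; within the scatter)) is expected to be small. Compound 4 is estimated at 2500 nM (expected range 700 nM to 7000 nM).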

Compound 4, half-maximal inhibitory concentration: 2600 nM
Compound 4: middle estimate off by 1.0-fold (0.02 log units), on the low side, within the range that was stated.
By their numbers in this assay, from the lowest: compounds 4, 3, 2 and 1 (each within the scatter of the next).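

In this assay, for the compounds shown here, methyl in place of hydrogen on the aromatic carbon para to a large group gives only a small step (a 1.2-fold lower number from compound 3 to compound 4 (0.06 log units; within the scatter)), the first reading for any change on the anilino ring. The (4-methylphenyl)amino group also cannot be told apart from 4-ethoxyphenyl (a 1.2-fold lower number from compound 2 to compound 4 (0.08 log units; within the scatter)) or from phenyl (a 1.9-fold lower number from compound 1 to compound 4 (0.28 log units; within the scatter)) at the carbon of the core that carries these groups. Nothing measured here bears on what lies behind these small steps.

On these data alone, whether any group at this place can move the number beyond the scatter stays open; a carboxylic acid, an amine or a longer chain in place of the methyl would test that. Also open, as far as these compounds go, is whether methyl on another carbon of that ring would give a similar result.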